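Aryl swap on the ring amide nitrogen: compound 3 to compound 4

The source may report more compounds than this note shows. Statements on the series, on what has been measured and on what is new or still open speak of the compounds shown alone.

Measured so far:
compound 1 `O=C1c2cc(COc3ccccc3)nn2CCN1c1ccccc1F` — 86%
compound 2 `Cc1ccc(N2CCn3nc(COc4ccccc4)cc3C2=O)cc1` — 65%
compound 3 `O=C1c2cc(COc3ccccc3)nn2CCN1c1cccnc1` — 64%

In a functional assay on HEK293 cells for positive allosteric modulation of metabotropic glutamate receptor 5 (Homo sapiens), read by calcium flux (a lower number here means a smaller maximal response, a higher number a larger maximal response), compound 3 gives 64%, the lowest of the three numbers. Against compound 2 the difference is a number 1 percentage points lower from compound 2 to compound 3 (within the scatter), so the two cannot be told apart; against compound 1 it is a number 22 percentage points lower from compound 1 to compound 3 (beyond the scatter), a real but modest drop.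

Compound 4 `COc1ccc(N2CCn3nc(COc4ccccc4)cc3C2=O)nc1` changes the group on the amide-type nitrogen in a ring: 5-methoxypyridin-2-yl in place of pyridin-3-yl on an amide-type nitrogen in a ring. Among the measured compounds shown here, no measured step covers this exact exchange. What bears on it are the two steps that alter the same aryl group: a number 21 percentage points lower from compound 1 to compound 2 (beyond the scatter) and a number 22 percentage points lower from compound 1 to compound 3 (beyond the scatter) show that leaving the 2-fluorophenyl of compound 1 lowers the maximal response modestly, while a number 1 percentage points lower from compound 2 to compound 3 (within the scatter) shows that two other aryl groups in that position give the same number within scatter. The series therefore offers no basis for a directional change from compound 3 to compound 4; the expected step in this assay is a number 2 percentage points higher from compound 3 to compound 4 (within the scatter), i.e. none beyond the scatter, with the range widened for the untested group.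

Estimate for compound 4 in this assay: 66%, expected range 50% to 84%.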

Compound 4, largest response reached (Emax), in percent of the reference or control that the assay uses: 74%
Compound 4: the middle estimate sits 8 percentage points below what was measured, and the stated range covers the measured number.
By their numbers in this assay, from the lowest: compounds 3, 2 and 4 (each within the scatter of the next); then compound 1.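

In this assay the 5-methoxypyridin-2-yl group on the amide-type nitrogen in a ring gives a number that cannot be separated from those of the pyridin-3-yl and 4-methylphenyl groups (a number 10 percentage points higher from compound 3 to compound 4 (within the scatter)) and (a number 9 percentage points higher from compound 2 to compound 4 (within the scatter)), so a methoxy-bearing pyridine with one more hydrogen-bond acceptor than pyridin-3-yl shows no loss of maximal response at this position. The same group still falls short of the 2-fluorophenyl (a number 12 percentage points lower from compound 1 to compound 4 (beyond the scatter)), which makes compound 1 the only one of the four whose steps to all the others lie beyond the scatter, now against three different aryl groups rather than two. Nothing in hand gives a reason for this order.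

A plain phenyl or a 2-chlorophenyl on the same nitrogen would help show whether the higher number of compound 1 goes with the fluorine or with the phenyl ring that carries it. The phenoxymethyl group is the same in all four compounds, so these data say nothing about how a benzyloxy or a pyridinyloxymethyl group there would behave.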